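Piperazine for Diethylamine on a Thiazolidinone Arylidene

The compounds below may be only part of what the source reports. "The series", "measured", "known", "first", "only" and "open" are said of these compounds alone.

Measured compounds:
compound 1, `CN1CCN(c2ccc(/C=C3/SC(Nc4ccccc4)=NC3=O)cc2)CC1`, 1400 nM
compound 2, `CCN(CC)c1ccc(/C=C2/SC(N(c3ccccc3)c3ccccc3)=NC2=O)cc1`, > 100000 nM

The account turns on compound 2 and the unmeasured compound 3. In a functional assay on NCI-H460 cells (Homo sapiens) for cytotoxicity, read by sulforhodamine B assay, with a stated time of 48 h (on this read-out higher numbers stand for an effect only at larger amounts of compound and lower numbers for an effect already at smaller amounts), compound 2 reaches only the limit of the assay, > 100000 nM, and no number is known for it. This is the limit named in the limit of > 100000 nM in this assay, at which 1 of the 2 values shown sits, at which one of the two measured values stands. Compound 1, `CN1CCN(c2ccc(/C=C3/SC(Nc4ccccc4)=NC3=O)cc2)CC1`, gives 1400 nM in this assay; compound 1 and compound 2 differ in more than one place, so their two values are all that can be said of that pair.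

Compound 3, `CN1CCN(c2ccc(/C=C3/SC(N(c4ccccc4)c4ccccc4)=NC3=O)cc2)CC1`, is reached from compound 2 by one change: 4-methylpiperazin-1-yl in place of diethylamino on an aromatic carbon. Among the compounds with values here, no measured step of this kind is available, so the size of the step is not known. Since compound 2 itself stands at the limit, the step is expected to stay small, with a lean toward somewhat more activity, and the estimate for the step is an at least 1.6-fold lower number from compound 2 to compound 3 (0.22 log units; that floor lies within the scatter). Compound 3 is therefore expected to give about 60000 nM, between 10000 nM and 300000 nM.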

Compound 3, half-maximal effective concentration: > 100000 nM
Compound 3 gave a limit, no number; the forecaster's own chance of this, stated with the estimate: 55%; middle value at least 1.6-fold (0.22 log units) away from the limit.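

Compound 3 does not bring the series off the limit in this assay. The step from diethylamino to 4-methylpiperazin-1-yl cannot be read, and with the second phenyl on the nitrogen in place, exchanging these two amines yields no number in either case, only the limit: the limit of > 100000 nM in this assay, at which 2 of the 3 values shown sit.

Within the data shown here, what the earlier compounds could not show is a readable comparison in one place: with 4-methylpiperazin-1-yl held fixed on the aromatic carbon, phenyl in place of hydrogen on the nitrogen gives an at least 71-fold higher number from compound 1 to compound 3 (1.85 log units; beyond the scatter), so that single exchange separates a measured value from a limit.

Still open, on these data alone, is how diethylamino would read with the hydrogen kept on that nitrogen, which would show whether 4-methylpiperazin-1-yl matters at all for the value of compound 1. Also open, as far as these compounds go, is whether a smaller group than phenyl on that nitrogen, such as methyl, or a morpholine in place of 4-methylpiperazin-1-yl, would give a number rather than a limit in this assay.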